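The compounds below may be only part of what the source reports. "The series", "measured", "known", "first", "only" and "open" are said of these compounds alone.

Working notes on the series.

Compound 1 `Oc1ccc(CN(Cc2ccccc2C(F)(F)F)Cc2ccc(O)c3ncccc23)c2cccnc12` is the reference point for this step. In a functional assay on U-87MG ATCC cells (Homo sapiens) for antiproliferative activity, with a stated time of 3 days (on this read-out higher numbers stand for an effect only at larger amounts of compound and lower numbers for an effect already at smaller amounts), compound 1 gives < 0.2 uM, which is a limit of the assay and not a number; it stands at the limit of < 0.2 uM in this assay, at which 1 of the 2 values shown sits. Compound 2 `CC(C)(C)OC(=O)N(Cc1ccc(C(F)(F)F)cc1)Cc1ccc(O)c2ncccc12` is the other measured member, and in this assay compound 2 gives 2 uM. For the measured compounds named here, no step between two measured compounds is available, so these two values show only that compound 2 lies at a measured number while compound 1 stops at the limit.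

Compound 3 `Oc1ccc(CN(Cc2ccc(O)c3ncccc23)Cc2ccc(O)c3ncccc23)c2cccnc12` remains to be measured. It differs from compound 1 by 8-hydroxyquinolin-5-yl in place of 2-(trifluoromethyl)phenyl on a saturated chain carbon bound to an amine nitrogen. Because compound 1 already sits at the limit of < 0.2 uM in this assay, at which 1 of the 2 values shown sits, a further gain cannot be read off from it. The step from compound 1 to compound 3 is expected to be none beyond the scatter a step that the limit leaves unreadable from compound 1 to compound 3. Compound 3 is therefore estimated at 0.15 uM in this assay, with an expected range from 0.03 uM to 0.8 uM.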

Compound 3, concentration for half-maximal effect: > 10 uM
Compound 3: only a limit was reported; the forecaster's own chance of this, stated with the estimate: 50%; at least 66-fold (1.82 log units) between middle value and limit.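

In this assay, this place on a saturated chain carbon bound to an amine nitrogen proves sensitive to the group it carries, with 8-hydroxyquinolin-5-yl in place of 2-(trifluoromethyl)phenyl giving an at least 50-fold higher number from compound 1 to compound 3 (1.69 log units; beyond the scatter). Compound 1 stands at a limit of the assay and not at a number: the limit of < 0.2 uM in this assay, at which 1 of the 3 values shown sits. Compound 3 also stands at a limit and not at a number: the limit of > 10 uM in this assay, at which 1 of the 3 values shown sits.

From the compounds shown here alone, it remains open whether activity at this place depends on the trifluoromethyl group itself, or whether a plain phenyl, a longer chain or a chain ending in a carboxylic acid would hold it. The cause of the loss also stays open, as the compounds shown carry no measured property that speaks to it.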